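The compounds below may be only part of what the source reports. "The series", "measured", "known", "first", "only" and "open" are said of these compounds alone.

The measured compounds in a functional assay on Z-138 cells (Homo sapiens) for inhibition, read by luminescence and CellTiter-Glo, with a stated time of 72 h; on this read-out lower numbers stand for stronger inhibition and higher numbers for weaker inhibition:
compound 1, `O=C(CCl)Nc1ccc(Cn2nc(-c3ccc(Oc4ccccc4)cc3)cc2C(=O)O)cc1`, 1500 nM;
compound 2, `C=CC(=O)Nc1ccc(Cn2nc(-c3ccc(Oc4ccccc4)cc3)cc2CO)cc1`, 6800 nM;
compound 3, `CCOC(=O)c1cc(-c2ccc(Oc3ccccc3)cc2)nn1Cc1ccc(NC(=O)CCl)cc1`, 400 nM.

Compound 1 gives the second highest of these three numbers: its nearest neighbour is compound 3, reached by a 3.8-fold lower number from compound 1 to compound 3 (0.57 log units; beyond the scatter), while compound 2 lies further away at the higher end. Compound 4, `O=C(CCl)Nc1cccc(Cn2nc(-c3ccc(Oc4ccccc4)cc3)cc2C(=O)O)c1`, has not been measured. It differs from compound 1 in one place: 3-(((chloromethyl)carbonyl)amino)phenyl in place of 4-(((chloromethyl)carbonyl)amino)phenyl on a saturated chain carbon bound to an aromatic nitrogen. No measured step bears on this change; the single step shown concerns another part of the molecule, and compound 2 differs from compound 1 in more than one place. With nothing to anchor it, a modest rise in this assay is expected, a 2.0-fold higher number from compound 1 to compound 4 (0.30 log units; within the scatter). Compound 4 is therefore estimated at 3000 nM, within 800 nM to 12000 nM.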

Compound 4, half-maximal inhibitory concentration: 9100 nM
Compound 4: the middle estimate sits 3.0-fold (0.48 log units) below what was measured, and the stated range covers the measured number.
By their numbers in this assay, from the lowest: compound 3; then compound 1; then compounds 2 and 4 (each within the scatter of the next).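

Moving the amide group on the phenyl ring, with the same atoms joined differently, gives a 6.1-fold higher number from compound 1 to compound 4 (0.78 log units; beyond the scatter) in this assay and so weakens inhibition. Among the compounds shown here, the earlier step changed only the other end of the molecule, so this is the first sign that the placement of this group matters, with 4-(((chloromethyl)carbonyl)amino)phenyl the better of the two in this acid series. No evidence is available to explain the difference. On these data alone, whether the same preference holds with the ethyl ester of compound 3 stays open, as does the effect of a plain amine in place of the chloromethyl amide.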